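Anilinopyrimidine benzothiazoles: isopropyl to methoxy swap

The source may hold more compounds than are shown below. What is called first, only, known or untested is meant among the compounds shown, and "the series" means these compounds.

Measured so far:
compound 1 `Cc1cnc(Nc2ccc(C(C)C)cc2)nc1Nc1nc2ccccc2s1` — > 50000 nM
compound 2 `Cc1ccc2nc(Nc3nc(Nc4ccc(S(C)(=O)=O)cc4)ncc3F)sc2c1` — 17200 nM

In a functional assay on HeLa cells (Homo sapiens) for antiproliferative activity, read by MTT assay, with a stated time of 48 h (on this read-out lower numbers stand for stronger inhibition and higher numbers for weaker inhibition), compound 1 gives only a limit, > 50000 nM, so its true value is not known. Compound 2 gives 17200 nM in this assay. Compound 3 `COc1ccc(Nc2ncc(C)c(Nc3nc4ccccc4s3)n2)cc1` follows from compound 1 by a single change, (methoxy in place of isopropyl on an aromatic carbon). Among the measured compounds shown here, no step between measured compounds bears on this change, and the starting point is itself uncertain because of the limit of > 50000 nM in this assay, at which 1 of the 2 values shown sits. The step of an at least 1.2-fold lower number from compound 1 to compound 3 (0.09 log units; that floor lies within the scatter) is therefore expected to be small and within scatter, with a fair chance of another limit. Compound 3 is estimated at 40000 nM, in the range 8000 nM to 100000 nM.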

Compound 3, half-maximal inhibitory concentration: > 50000 nM
Compound 3: only a limit was reported; the forecaster's own chance of this, stated with the estimate: 50%; middle value at least 1.2-fold (0.09 log units) from the limit.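

No step can be read from compound 1 to compound 3, since both results in this assay are limits: the limit of > 50000 nM in this assay, at which 2 of the 3 values shown sit.

The compounds shown leave open whether methoxy in place of isopropyl changes the activity of the shared core at all.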